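Series notes: naphthalen-1-yl in place of 4-chlorophenyl

The source may report more compounds than this note shows. Statements on the series, on what has been measured and on what is new or still open speak of the compounds shown alone.

Measured so far in an ADME assay on GES1 cells (Homo sapiens) for inhibition, read by MTT assay, with a stated time of 72 h (a lower number here means a stronger inhibitor, a higher number a weaker inhibitor), with the shared core:
- compound 1 `Cc1cc(Nc2cc(-c3ccccc3)[nH]n2)n2nc(SCC(=O)c3ccccc3)nc2n1` gives 33300 nM
- compound 2 `Cc1cc(Nc2cc(-c3ccccc3)[nH]n2)n2nc(SCc3ccc(Cl)cc3)nc2n1` gives 31800 nM

Compound 2 at 31800 nM stands level with compound 1, the two values lying within the scatter of each other. There is no third number to compare them with.

Compound 3 `Cc1cc(Nc2cc(-c3ccccc3)[nH]n2)n2nc(SCc3cccc4ccccc34)nc2n1` has not yet been measured. Its change from compound 2 puts naphthalen-1-yl in place of 4-chlorophenyl on a saturated chain carbon bound to a sulfur. Among the measured compounds shown here, only one measured step bears on this place (a 1.0-fold lower number from compound 1 to compound 2 (0.02 log units; within the scatter)). It put 4-chlorophenyl in place of benzoyl and stayed within the scatter. For the measured compounds named here, that is thin evidence, and no measured compound carries naphthalen-1-yl. No step beyond the scatter is therefore expected in this assay, and no direction can be named. The estimated step is small (a 1.1-fold lower number from compound 2 to compound 3 (0.06 log units; within the scatter)). Expected for compound 3 is 28000 nM (estimated range 12000 nM to 60000 nM).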

Compound 3, half-maximal inhibitory concentration: 36300 nM
Compound 3: the middle estimate sits 1.3-fold (0.11 log units) below what was measured; low and high end bracket the measured number.
By their numbers in this assay, from the lowest: compounds 2, 1 and 3 (each within the scatter of the next).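

In this assay, naphthalen-1-yl in place of 4-chlorophenyl on a saturated chain carbon bound to a sulfur gives a 1.1-fold higher number from compound 2 to compound 3 (0.06 log units; within the scatter), and naphthalen-1-yl in place of benzoyl at the same place gives a 1.1-fold higher number from compound 1 to compound 3 (0.04 log units; within the scatter). The earlier pair showed only that a benzoyl and a 4-chlorophenyl group read alike here; this result adds that 10 heavy atoms in place of 7, a second six-membered aromatic ring and the absence of the chlorine also leave the number within the scatter, so all three compounds stand level. No supporting data on the properties of these groups accompany the result.

From the compounds shown here alone, all three groups at this place carry carbon-only aromatic rings, so it remains open whether a simple amine, a carboxylic acid or a longer saturated chain there would give a step beyond the scatter. With every step so far within the scatter, the compounds shown also leave open how large a step any change at this place can produce in this assay.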